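This account rests on a few compounds, and the source may have more. Where it says the series, first, only, none or still open, it means among the compounds named here.

Compound 1, `O=C(OCC1CCCNC1)c1ccccc1-c1ccccc1`, is the starting point of this account. In an in vitro functional assay on HEK ts201 cells for antagonist activity at Neuronal acetylcholine receptor; alpha4/beta2 (Homo sapiens), read by fluorescence and calcium flux (on this read-out lower numbers stand for stronger inhibition and higher numbers for weaker inhibition), compound 1 gives 7080 nM, the lower of the two values recorded so far. The other measured compound, compound 2, `CC1CC(=O)N(c2ccccc2C(=O)OCC2CCCN(CCCCCOc3ccccc3)C2)C1=O`, gives 17000 nM in this assay, a higher number that lies beyond the usual scatter of repeat measurements. For the measured compounds named here, no pair differing in one place has been measured, so no computed step is available to guide the next move.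

Compound 3, `C[N+]1(C)CCCC(COC(=O)c2ccccc2-c2ccccc2)C1`, has not yet been tested in this assay. Its structure differs from compound 1 by a group of 8 heavy atoms (7 carbon, 1 nitrogen; one six-membered non-aromatic ring with 1 hetero atom) in place of a group of 6 heavy atoms (5 carbon, 1 nitrogen; one six-membered non-aromatic ring with 1 hetero atom), on a saturated chain carbon bound to an oxygen next to a carbonyl group. The group that enters carries a net charge of +1 and offers no hydrogen-bond donor or acceptor, whereas the piperidin-3-yl that leaves offers one of each.

Going by the values given here, with no measured step of the same kind, compound 3 is expected to land near compound 1, a step of a 1.4-fold lower number from compound 1 to compound 3 (0.15 log units; within the scatter), and its estimated value in this assay is 5000 nM, in the range from 1500 nM to 20000 nM.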

Compound 3, half-maximal inhibitory concentration: 2400 nM
For compound 3 the middle estimate is 2.1-fold (0.32 log units) above the measured one; the range from low to high includes it.
By their numbers in this assay, from the lowest: compound 3; then compound 1; then compound 2.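

For the compounds shown here, this is the first step that can be read in this assay: on a saturated chain carbon bound to an oxygen next to a carbonyl group, the group with a net charge of +1 in place of piperidin-3-yl gives a 3.0-fold lower number from compound 1 to compound 3 (0.47 log units; beyond the scatter). The change is modest, but it shows that this place accepts two more heavy atoms and the loss of the hydrogen-bond donor and acceptor counted on piperidin-3-yl without the number rising. No independent evidence accounts for this step.

The net charge, the added atoms and the lost donor and acceptor all change together, so their separate contributions cannot be told apart. A comparison with 1-methylpiperidin-3-yl, or with a ring bearing two ethyl groups on its nitrogen, would leave open how far each contributes.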